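Hydroxy to methyl on the sulfonyl-linked ring

The compounds below may be only part of what the source reports. "The series", "measured", "known", "first", "only" and "open" are said of these compounds alone.

The series shares one core: compound 1 `CC(O)(C(=O)Nc1ccc(S(=O)(=O)c2ccccc2O)cc1)C(F)(F)F`, compound 2 `CC(O)(C(=O)Nc1ccc(S(=O)(=O)c2cccc(O)c2)cc1)C(F)(F)F` and compound 3 `COc1cc(NC(=O)C(C)(O)C(F)(F)F)ccc1S(=O)(=O)c1ccccc1`, all measured in a functional assay (Cavia porcellus) with sulfonylurea receptors; K-ATP channels (Homo sapiens) as the target; on this read-out lower numbers stand for stronger inhibition and higher numbers for weaker inhibition. Going by the values given here, compound 1 gives 3090 nM, compound 3 gives 5900 nM, and compound 2 gives 18000 nM, the highest number of the three; the only single-point step, a 5.8-fold higher number from compound 1 to compound 2 (0.77 log units; beyond the scatter), is a modest rise. Compound 4 `Cc1cccc(S(=O)(=O)c2ccc(NC(=O)C(C)(O)C(F)(F)F)cc2)c1` differs from compound 2 by methyl in place of hydroxy on an aromatic carbon. Among the compounds with values here, no measured step removes a hydroxy outright, so the direction rests on the weak showing of compound 2 alone. A modest lower number is expected, a 3.0-fold lower number from compound 2 to compound 4 (0.48 log units; beyond the scatter), with wide uncertainty. Compound 4 is estimated at 6000 nM, range 1500 nM to 25000 nM.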

Compound 4, half-maximal inhibitory concentration: 2200 nM
Beside the measured number, compound 4's estimate is 2.7-fold (0.44 log units) above it, and the stated range covers the measured number.
By their numbers in this assay, from the lowest: compounds 4, 1 and 3 (each within the scatter of the next, the first and the last beyond it); then compound 2.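

In this assay the change from 3-hydroxyphenyl to 3-methylphenyl gives an 8.2-fold lower number from compound 2 to compound 4 (0.91 log units; beyond the scatter) and so ties the high number of compound 2 to the hydroxy at this place, not to the presence of a group there. With a 1.4-fold lower number from compound 1 to compound 4 (0.15 log units; within the scatter) the 3-methylphenyl and 2-hydroxyphenyl rings cannot be told apart, so a hydroxy on this ring is not required for a number in this range. Nothing at hand explains the step.

Open, from the compounds shown here alone, is whether an amine, a chlorine or a longer chain such as ethyl at this place would read like the methyl or like the hydroxy.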